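Pyrimidin-2-yl in place of diethylcarbamoyl

A few compounds are considered here, and "the series" means these few. Any claim that something is new, unique, unknown or untested is made for them only; others in the source may bear on it.

In an in vitro ADME assay on microsomes from liver (Mus musculus) for pharmacokinetics, read by LC-MS, with a stated time of 10 min, tested at 1 uM (on this read-out lower numbers stand for slow clearance and higher numbers for fast clearance), compound 3 (`CCN(CC)C(=O)N1C[C@H](C(=O)Nc2ccc(Cl)cc2)[C@@H](c2ccc(/C=C/C(=O)Nc3ccccc3N)cc2)C1`) gives 83 mL/min/kg and lies within the scatter of compound 1 (`Nc1ccccc1NC(=O)/C=C/c1ccc([C@H]2CN(C3COC3)C[C@@H]2C(=O)Nc2ccc(Cl)cc2)cc1`) at 42 mL/min/kg but well clear of compound 2 (`CC(C)(C)N1C[C@H](C(=O)Nc2ccc(Cl)cc2)[C@@H](c2ccc(/C=C/C(=O)Nc3ccccc3N)cc2)C1`) at 20 mL/min/kg on the low side. Compound 4 (`Nc1ccccc1NC(=O)/C=C/c1ccc([C@H]2CN(c3ncccn3)C[C@@H]2C(=O)Nc2ccc(Cl)cc2)cc1`) has pyrimidin-2-yl in place of diethylcarbamoyl on an amine nitrogen in a ring. Three measured steps at that nitrogen bear on this: a 2.1-fold lower number from compound 1 to compound 2 (0.32 log units; beyond the scatter) is modest and so is a 4.2-fold higher number from compound 2 to compound 3 (0.62 log units; beyond the scatter) while a 2.0-fold higher number from compound 1 to compound 3 (0.30 log units; within the scatter) stays within the scatter. None of them involves pyrimidin-2-yl, so only a small change can be expected: a 1.7-fold lower number from compound 3 to compound 4 (0.22 log units; within the scatter) is the expected step, no larger than those. Compound 4 is estimated at 50 mL/min/kg with a range of 22 mL/min/kg to 105 mL/min/kg as the expected span.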

Compound 4, clearance: 44 mL/min/kg
For compound 4 the middle estimate is 1.1-fold (0.06 log units) above the measured one; low and high end bracket the measured number.
By their numbers in this assay, from the lowest: compound 2; then compounds 1, 4 and 3 (each within the scatter of the next).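

In this assay, an aromatic ring on this amine nitrogen reads the same within the scatter as diethylcarbamoyl (a 1.9-fold lower number from compound 3 to compound 4 (0.28 log units; within the scatter)) and oxetan-3-yl (a 1.0-fold higher number from compound 1 to compound 4 (0.02 log units; within the scatter)). Only tert-butyl stands apart from pyrimidin-2-yl, and modestly so (a 2.2-fold higher number from compound 2 to compound 4 (0.34 log units; beyond the scatter)), which leaves compound 2 as the one clear outlier among the four compounds. No measured evidence accounts for these numbers.

Going by these compounds, whether a plain phenyl ring or an acetyl group on this nitrogen would stay with compound 4 or move toward compound 2 remains open.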